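Benzyl variation in the series, compound 2 to compound 3

A few compounds are considered here, and "the series" means these few. Any claim that something is new, unique, unknown or untested is made for them only; others in the source may bear on it.

Going by the values given here, the shared core is carried unchanged through the two members measured so far. Compound 1 `Cc1ccc(Cn2cc(COc3ccc4c(=O)ccoc4c3)nn2)cc1` and compound 2 `O=c1ccoc2cc(OCc3cn(Cc4ccccc4Cl)nn3)ccc12` were both read in a functional assay on SW480 cells (Homo sapiens) for cytotoxicity, read by MTT assay, with a stated time of 48 h; a higher number here means a weaker inhibitor, a lower number a stronger inhibitor; compound 1 gives 10400 nM and compound 2 gives 23500 nM. Among the compounds with values here, the only measured comparison is a 2.3-fold higher number from compound 1 to compound 2 (0.35 log units; beyond the scatter). Among the two numbers, compound 2 stands highest, with compound 1 its single neighbour at a lower value.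

Compound 3 `COc1ccc(Cn2cc(COc3ccc4c(=O)ccoc4c3)nn2)cc1` is the next member. Its change from compound 2 is 4-methoxyphenyl in place of 2-chlorophenyl on a saturated chain carbon bound to an aromatic nitrogen; cut one bond further out, it reads 2-chlorobenzyl to 4-methoxybenzyl. Within the data shown here, the one step that bears on it is a 2.3-fold higher number from compound 1 to compound 2 (0.35 log units; beyond the scatter), in which 4-methylphenyl gave way to 2-chlorophenyl at the same place and the number rose. Compound 3 moves back toward the kind of group present in compound 1, with 4-methoxyphenyl rather than 4-methylphenyl, so a drop of about the same size is expected, as a 2.1-fold lower number from compound 2 to compound 3 (0.33 log units; beyond the scatter). Compound 3 is therefore estimated at 11000 nM, with a range of 4500 nM to 28000 nM.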

Compound 3, half-maximal inhibitory concentration: 20400 nM
Compound 3: middle estimate off by 1.9-fold (0.27 log units), on the low side; measured number inside the range.
By their numbers in this assay, from the lowest: compounds 1, 3 and 2 (each within the scatter of the next, the first and the last beyond it).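

In this assay, 4-methoxyphenyl in place of 2-chlorophenyl gives a 1.2-fold lower number from compound 2 to compound 3 (0.06 log units; within the scatter), and methoxy in place of methyl on an aromatic carbon gives a 2.0-fold higher number from compound 1 to compound 3 (0.29 log units; within the scatter). Going by these compounds alone, on a saturated chain carbon bound to an aromatic nitrogen, 4-methoxyphenyl therefore cannot be told apart from either of the other two groups, and the only step beyond the scatter remains a 2.3-fold higher number from compound 1 to compound 2 (0.35 log units; beyond the scatter), which compound 3 neither extends nor clearly assigns to one side of the series. No supporting measurement is available to explain these numbers.

Within the data shown here, open is whether the single step beyond the scatter follows from the chlorine, from where the substituent sits on the phenyl ring, or from neither, since compound 2 changes both at once and no compound separates the two. Also open is whether this position tolerates groups of a different kind, such as an unsubstituted phenyl, an amine or a carboxylic acid on the phenyl ring, or a longer chain to the aromatic nitrogen, all of which lie outside the three compounds shown.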